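The source may hold more compounds than are shown below. What is called first, only, known or untested is meant among the compounds shown, and "the series" means these compounds.

Measured in a functional assay on DU-145 cells (Homo sapiens) for inhibition, read by trypan blue exclusion, with a stated time of 72 h; a lower number here means a stronger inhibitor, a higher number a weaker inhibitor:
- compound 1 `Cn1c(=O)c(S(=O)(=O)c2ccc(F)cc2)cc2cnc(Nc3ccc4[nH]ccc4c3)nc21` gives 300 nM
- compound 2 `Cn1c(=O)c(S(=O)(=O)c2ccc(F)cc2[N+](=O)[O-])cc2cnc(Nc3ccc4[nH]ccc4c3)nc21` gives 1500 nM

Of these two, compound 2 has the higher number, 1500 nM, and so is the weaker inhibitor. The next compound, compound 3 `Cn1c(=O)c(S(=O)(=O)c2ccc([N+](=O)[O-])cc2F)cc2cnc(Nc3ccc4[nH]ccc4c3)nc21`, has the same atoms as compound 2, joined differently: 2-fluoro-4-nitrophenyl in place of 4-fluoro-2-nitrophenyl on a sulfonyl sulfur. In words, 2-fluoro-4-nitrophenyl stands in place of 4-fluoro-2-nitrophenyl on a sulfonyl sulfur.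

Going by the values given here, only one measured step bears on this change. Nitro in place of hydrogen on an aromatic carbon gave a 5.0-fold higher number from compound 1 to compound 2 (0.70 log units; beyond the scatter), a modest step. Among the compounds with values here, no measured pair shows what happens when the nitro group changes its place on the ring, so the direction of such a change is poorly defined. Compound 3 still carries a nitro group, so it is expected to stay closer to compound 2 at 1500 nM than to compound 1 at 300 nM, with perhaps a slight recovery. The estimate means a 1.5-fold lower number from compound 2 to compound 3 (0.18 log units; within the scatter), an expected shift that stays within the scatter. In this assay, the estimated value for compound 3 is 1000 nM, with an expected range from 300 nM to 3500 nM.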

Compound 3, half-maximal inhibitory concentration: 400 nM
Compound 3: the middle estimate sits 2.5-fold (0.40 log units) above what was measured; measured number inside the range.
By their numbers in this assay, from the lowest: compounds 1 and 3 (each within the scatter of the next); then compound 2.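

In this assay, the arrangement of the two groups on the aromatic ring matters: moving from 4-fluoro-2-nitrophenyl to 2-fluoro-4-nitrophenyl on the sulfonyl sulfur, with the same atoms joined differently, gave a 3.8-fold lower number from compound 2 to compound 3 (0.57 log units; beyond the scatter) and so undid most of what the earlier pair had seemed to show. That pair alone could be read as a cost of carrying a nitro group at all, yet 2-fluoro-4-nitrophenyl in place of 4-fluorophenyl gave a 1.3-fold higher number from compound 1 to compound 3 (0.12 log units; within the scatter) and so cannot be told apart from the parent. Among these three compounds, then, the higher number goes with the 4-fluoro-2-nitrophenyl group of compound 2 and not with the nitro group as such, and compound 3 is the one that goes against the simpler reading.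

No measured information is at hand to explain why the two arrangements differ. From the compounds shown here alone, whether an amine or a nitrile in place of the nitro group of compound 3 would hold its number remains open, as does what the fluorine contributes in either arrangement.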